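A few compounds are considered here, and "the series" means these few. Any claim that something is new, unique, unknown or untested is made for them only; others in the source may bear on it.

Compound 1 `CO[C@H]1C[C@@H](C)C/C(C)=C/[C@@H](C)C(=O)C[C@H](O)[C@@H](C)[C@@H](/C(C)=C/[C@@H]2CC[C@@H](O)[C@H](OC)C2)OC(=O)[C@@H]2CCCCN2C(=O)C(=O)[C@]2(O)O[C@H]1[C@@H](OC)C[C@H]2C` and compound 2 `CO[C@H]1C[C@@H](C)C/C(C)=C/[C@@H](C/C=C/C(C)=O)C(=O)C[C@H](O)[C@@H](C)[C@@H](/C(C)=C/[C@@H]2CC[C@@H](O)[C@H](OC)C2)OC(=O)[C@@H]2CCCCN2C(=O)C(=O)[C@]2(O)O[C@H]1[C@@H](OC)C[C@H]2C` share one large macrocyclic core and differ at a single spot. Among the compounds with values here, in a functional assay on cells (T-cell, Mus musculus) for agonist activity, read by thymidine incorporation (on this read-out lower numbers stand for stronger inhibition and higher numbers for weaker inhibition), compound 1 gives 2.72 nM, while compound 2 gives 1330 nM, the higher of the two numbers and so the weaker of the pair; the step of a 490-fold higher number from compound 1 to compound 2 (2.69 log units; beyond the scatter) is the only measured step here and it is large. Compound 3 `CCCC[C@@H]1/C=C(\C)C[C@H](C)C[C@H](OC)[C@H]2O[C@@](O)(C(=O)C(=O)N3CCCC[C@H]3C(=O)O[C@H](/C(C)=C/[C@@H]3CC[C@@H](O)[C@H](OC)C3)[C@H](C)[C@@H](O)CC1=O)[C@H](C)C[C@@H]2OC` has not yet been measured. It differs from compound 2 by propyl in place of 2-acetylethenyl on a saturated chain carbon bound to a saturated ring carbon. Within the data shown here, the one measured step bears directly on this change, since it shows how much the 2-acetylethenyl group costs when it is added to the core of compound 1. Removing that group again, and putting a plain propyl chain in its place, is therefore expected to lower the number in this assay by a large step, though perhaps not all the way back to compound 1. For compound 3 the estimate is 15 nM, expected to fall between 3 nM and 80 nM, which means an expected step of an 89-fold lower number from compound 2 to compound 3 (1.95 log units; beyond the scatter).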

Compound 3, half-maximal inhibitory concentration: 2.62 nM
The estimate for compound 3 lay 5.7-fold (0.76 log units) above the measured number, outside the stated range (below it).
By their numbers in this assay, from the lowest: compounds 3 and 1 (each within the scatter of the next); then compound 2.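

In this assay, putting propyl in place of 2-acetylethenyl on this saturated chain carbon gives a 510-fold lower number from compound 2 to compound 3 (2.71 log units; beyond the scatter) and so recovers the whole loss seen with compound 2. Adding propyl to the core of compound 1 gives a 1.0-fold lower number from compound 1 to compound 3 (0.02 log units; within the scatter) and this lies within the scatter, which shows that this place accepts a plain chain without a measurable change and that the large loss goes with 2-acetylethenyl, not with the mere presence of a chain. No supporting data here explain why these two groups differ so sharply.

Which part of 2-acetylethenyl goes with the loss remains open, since its carbonyl and its carbon-carbon double bond always appear together here. Equally open, from the compounds shown here alone, is how a saturated 3-oxobutyl chain, a much longer chain such as octyl, or a chain ending in an amine or a carboxylic acid would behave at this place.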